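The source may report more compounds than this note shows. Statements on the series, on what has been measured and on what is new or still open speak of the compounds shown alone.

In an assay on isolated protein (blood) for antagonist activity at C-C chemokine receptor type 4 (Homo sapiens), read by flow cytometry, with a stated time of 30 min (a higher number here means weaker binding, a lower number tighter binding), compound 3 `COc1cccc2c1c(NS(=O)(=O)c1ccc(Cl)s1)nn2Cc1cccc(CNC(=O)C2CCCO2)c1` gives 794 nM, the lowest of the three numbers recorded. Compound 1 `CC(=O)NCc1cccc(Cn2nc(NS(=O)(=O)c3ccc(Cl)s3)c3c(F)cccc32)c1` gives 5010 nM in this assay, and compound 2 `CC(=O)NCc1cccc(Cn2nc(NS(=O)(=O)c3ccc(Cl)s3)c3c(C(F)F)cccc32)c1` gives 7940 nM. Within the data shown here, the only measured single-point step, a 1.6-fold higher number from compound 1 to compound 2 (0.20 log units; within the scatter), concerns a substituent on the aromatic ring and not the amide end of the molecule. Compound 4 `CN[C@H](C)C(=O)NCc1cccc(Cn2nc(NS(=O)(=O)c3ccc(Cl)s3)c3c(OC)cccc32)c1` differs from compound 3 by 1-(methylamino)ethyl in place of oxolan-2-yl on a carbonyl carbon. Among the measured compounds shown here, no measured step touches this amide substituent, so there is no precedent for the change. Compound 4 is therefore expected to sit near compound 3, with a 1.3-fold lower number from compound 3 to compound 4 (0.10 log units; within the scatter) as the estimated step. Compound 4 is thus estimated at 630 nM in this assay, within an expected range from 160 nM to 2500 nM.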

Compound 4, dissociation constant: 200 nM
Compound 4: middle estimate off by 3.2-fold (0.50 log units), on the high side; measured number inside the range.
By their numbers in this assay, from the lowest: compound 4; then compound 3; then compounds 1 and 2 (each within the scatter of the next).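

Among these compounds, putting 1-(methylamino)ethyl in place of oxolan-2-yl on a carbonyl carbon gives a 4.0-fold lower number from compound 3 to compound 4 (0.60 log units; beyond the scatter) in this assay and so shows that this amide substituent, which no earlier step touched, can move the number beyond the scatter. The change removes a ring and adds a hydrogen-bond donor and a defined stereocentre all at once, and this single pair cannot separate them. No evidence available bears on why the number moved. Going by these compounds, it remains open how an aminomethyl group, a dimethylamino-bearing chain or the opposite stereoisomer of 1-(methylamino)ethyl would compare on this carbonyl carbon.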